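The source may report more compounds than this note shows. Statements on the series, on what has been measured and on what is new or still open speak of the compounds shown alone.

Measured in a functional assay on DU-145 cells (Homo sapiens) for inhibition, read by trypan blue exclusion, with a stated time of 96 h; a lower number here means a stronger inhibitor of growth, a higher number a weaker inhibitor of growth:

- Compound 1 `O=C(/C(=C\c1ccc(Cl)cc1)SCc1ccc(Cl)cc1)c1ccc(Br)cc1`: 10000 nM
- Compound 2 `Cc1ccc(S/C(=C/c2ccc(N(C)C)cc2)C(=O)c2ccc(Br)cc2)cc1`: > 100000 nM (a limit, not a number)

Compound 2 has only a limit on these numbers, (the limit of > 100000 nM in this assay, at which 1 of the 2 values shown sits), and no measured value. Compound 3 `CN(C)c1ccc(/C=C(/SCc2ccc(Cl)cc2)C(=O)c2ccc(Br)cc2)cc1` is still unmeasured. It differs from compound 2 by 4-chlorobenzyl in place of 4-methylphenyl on a sulfur and is otherwise unchanged. Among the measured compounds shown here, no step between measured compounds is available to size this change. The expectation rests on compound 1, which carries 4-chlorobenzyl on its sulfur and gives 10000 nM in this assay as a measured number. A move towards a stronger inhibitor of growth is therefore expected, with an estimated step of an at least 10-fold lower number from compound 2 to compound 3 (1.00 log units; beyond the scatter) that remains uncertain in size. For compound 3 the expected value is 10000 nM, with an estimated range from 1500 nM to 70000 nM.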

Compound 3, concentration for 50% growth inhibition: 10000 nM
Estimate against measurement, compound 3: no gap at the digits printed; measured number inside the range.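

In this assay, among the compounds shown here, 4-chlorobenzyl in place of 4-methylphenyl on a sulfur gives an at least 10-fold lower number from compound 2 to compound 3 (1.00 log units; beyond the scatter), the first sized change at this position. Compound 2 is held only by a limit, not a number, so this size is a floor: the limit of > 100000 nM in this assay, at which 1 of the 3 values shown sits. With 4-chlorobenzyl on the sulfur, dimethylamino in place of chloro on an aromatic carbon gives no change at the digits printed from compound 1 to compound 3 (within the scatter), so this single pair shows no effect of that swap on the read-out.

The compounds shown do not separate the chloro group from the benzyl part of the sulfur change; an unsubstituted benzyl or a 4-methylbenzyl on the same sulfur would do so. As far as these compounds go, how a carboxylic acid or a morpholine in place of dimethylamino would read also stays open.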